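This account rests on a few compounds, and the source may have more. Where it says the series, first, only, none or still open, it means among the compounds named here.

Measured so far:
compound 1, `Cc1cn([C@H]2C[C@H](O)[C@@H](OP(=O)(O)O)O2)c(=O)[nH]c1=O`, 138000000 nM
compound 2, `CCc1cn([C@H]2C[C@H](O)[C@@H](OP(=O)(O)O)O2)c(=O)[nH]c1=O`, 28200000 nM

Both compounds were tested in an assay on L1210 cells for inhibition of Thymidylate synthase (Mus musculus); on this read-out lower numbers stand for stronger inhibition and higher numbers for weaker inhibition. Compound 1 gives 138000000 nM, and compound 2 gives 28200000 nM. Among the compounds with values here, the one step that joins them is a 4.9-fold lower number from compound 1 to compound 2 (0.69 log units; beyond the scatter). Within the data shown here, on these two numbers, compound 2 stands at the lower, stronger end, and its only neighbour, compound 1, sits a clear distance above it.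

Compound 3, `CCCc1cn([C@H]2C[C@H](O)[C@@H](OP(=O)(O)O)O2)c(=O)[nH]c1=O`, has not yet been measured. It differs from compound 2 by methyl in place of hydrogen on a saturated chain carbon, two bonds along the chain from an aromatic carbon, the same kind of chain lengthening as in the measured step, carried one bond further out. Among the measured compounds shown here, only the step from compound 1 to compound 2 bears on it, and it went in the favourable direction by a modest margin. Whether a second such lengthening continues that trend is not shown by any measured pair, so the expectation is a smaller gain than before, or possibly none beyond the scatter. Compound 3 is therefore estimated at 14000000 nM, within a range of 4000000 nM to 50000000 nM. That estimate corresponds to an expected step of a 2.0-fold lower number from compound 2 to compound 3 (0.30 log units; within the scatter).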

Compound 3, inhibition constant: 8130000 nM
Beside the measured number, compound 3's estimate is 1.7-fold (0.24 log units) above it; the measured number falls inside the stated range.
By their numbers in this assay, from the lowest: compound 3; then compound 2; then compound 1.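

In this assay, going from ethyl to propyl gives a 3.5-fold lower number from compound 2 to compound 3 (0.54 log units; beyond the scatter) and so the gain seen with the first added carbon did not stop at ethyl: this position still responds when the chain grows one bond further out. Across the whole series, the change from methyl to propyl gives a 17-fold lower number from compound 1 to compound 3 (1.23 log units; beyond the scatter) and each added carbon lowers the number, with no compound of the three going against this, which leaves compound 3 as the strongest inhibitor of the three at 8130000 nM on this read-out. Nothing available here explains why the longer chains give lower numbers.

As far as these compounds go, how far the trend runs remains open, since three compounds cannot show whether a butyl or a longer chain would lower the number further or whether the series turns back at some length. From the compounds shown here alone, it is also open whether only the length of the chain matters, a question that a branched group such as isopropyl, or a chain ending in a hydroxyl or an amine, could begin to answer.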